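Two inactive analogues, one weak number, a third aryl swap

This account rests on a few compounds, and the source may have more. Where it says the series, first, only, none or still open, it means among the compounds named here.

The study, read in a functional assay on K562 cells (Homo sapiens) for cytotoxicity, read by CCK-8 assay, with a stated time of 72 h (on this read-out lower numbers stand for stronger inhibition and higher numbers for weaker inhibition), offers a narrow set of results. In this assay compound 1 `COc1ccccc1/C=c1/[nH]c(=O)/c(=C\c2cccc(Cl)c2Cl)[nH]c1=O` is recorded as "not active" (no number reported), without a number attached. Likewise, in this assay compound 2 `C=CCn1c(=O)/c(=C\c2ccc(Cl)c(Cl)c2)[nH]c(=O)/c1=C\c1ccccc1OC` is recorded as "not active" (no number reported), again with no number. For the measured compounds named here, that leaves compound 3 `C=CCn1c(=O)/c(=C\c2cc(Br)ccc2F)[nH]c(=O)/c1=C\c1ccccc1OC` as the sole member with a measured half-maximal inhibitory concentration: in this assay compound 3 gives 5100 nM. Compound 3 therefore stands alone on the numbers shown, with nothing else to rank it against beyond the two entries that carry no value at all.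

Compound 4 `C=CCn1c(=O)/c(=C\c2ccccc2C(F)(F)F)[nH]c(=O)/c1=C\c1ccccc1OC` is the next candidate. The change from compound 3 is 2-(trifluoromethyl)phenyl in place of 5-bromo-2-fluorophenyl on a double-bonded chain carbon bound to an aromatic carbon. Going by the values given here, no step between measured compounds is available to calibrate what such a swap does in this assay, and the two inactive neighbours suggest the series sits close to the edge of what the read-out can resolve. He expects the step from compound 3 to compound 4 to be a 1.6-fold higher number from compound 3 to compound 4 (0.20 log units; within the scatter), toward weaker inhibition but not by more than the scatter allows one to trust. Compound 4 is accordingly estimated at 8000 nM, with a range from 2500 nM to 30000 nM.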

Compound 4, half-maximal inhibitory concentration: 2700 nM
Compound 4: middle estimate off by 3.0-fold (0.47 log units), on the high side; low and high end bracket the measured number.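

In this assay the exchange gives a 1.9-fold lower number from compound 3 to compound 4 (0.28 log units; within the scatter) and so separates the two compounds by no more than the scatter, even though 2-(trifluoromethyl)phenyl has 10 heavy atoms and no bromine, while 5-bromo-2-fluorophenyl has 8. The position on a double-bonded chain carbon bound to an aromatic carbon therefore now has two different substituted phenyl groups with a number attached. Compound 3 and compound 4 both differ from compound 2 only at this position, and in the same assay compound 2 is recorded as "not active" (no number reported). No independent measurement is available to explain either the close agreement of these two numbers or the lack of a number for compound 2.

From the compounds shown here alone, what remains open is whether a phenyl group carrying an amine, a carboxylic acid or a nitrile at this position would yield a number in this assay and how it would compare with those of compound 3 and compound 4. Also unsettled is whether an unsubstituted phenyl group here would give a reading in the same range or none at all.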